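The compounds below may be only part of what the source reports. "The series", "measured", "known", "first", "only" and "open" are said of these compounds alone.

The measured compounds in an ADME assay on MCF-10A cells (Homo sapiens) for cytotoxicity, read by MTT assay, with a stated time of 72 h; on this read-out lower numbers stand for stronger inhibition of growth and higher numbers for weaker inhibition of growth:
compound 1 `CS/C(=N\C(=O)c1ccno1)NC(=O)c1ccno1` gives > 100000 nM, which is a limit of the assay and not a number;
compound 2 `O=C(/N=C(/NC(=O)c1csc([N+](=O)[O-])c1)[Se]Cc1ccccc1)c1csc([N+](=O)[O-])c1` gives 54100 nM;
compound 3 `C[Se]/C(=N\C(=O)c1csc([N+](=O)[O-])c1)NC(=O)c1csc([N+](=O)[O-])c1` gives 4740 nM.

Compound 1 thus stands at the limit of > 100000 nM in this assay, at which 1 of the 3 values shown sits, so its inhibition of growth is too weak to be given as a number here. Compound 4 `O=C(/N=C(/NC(=O)c1ccno1)[Se]Cc1ccccc1)c1ccno1` is not yet measured. It differs from compound 1 in one place: a group of 8 heavy atoms (7 carbon, 1 selenium; one six-membered aromatic ring of carbon only) in place of a group of 2 heavy atoms (1 carbon, 1 sulfur; no ring), on a carbon with a double bond to nitrogen. Among the compounds with values here, the only measured step that bears on this change runs the opposite way, hydrogen in place of phenyl on a saturated chain carbon bound to a selenium atom: an 11-fold lower number from compound 2 to compound 3 (1.06 log units; beyond the scatter). Read backwards, that step says that putting the phenyl-bearing group in place of the small group made the number larger, meaning weaker inhibition of growth. Within the data shown here, no measured step covers the exchange of sulfur for selenium on its own. Since compound 1 already sits at the limit, compound 4 is expected to inhibit growth no more strongly, most likely again reported only as a limit, with an estimated step that the limit leaves unreadable from compound 1 to compound 4. The estimate for compound 4 is 250000 nM, with a range from 60000 nM to 1500000 nM.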

Compound 4, concentration for total growth inhibition: > 100000 nM
Compound 4 ended at the assay's limit (the forecaster's own chance of this, stated with the estimate: 80%); the middle value is on the limit's open side.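

Compound 1 and compound 4 both give a limit of the assay and not a number, so the step between them cannot be read: the limit of > 100000 nM in this assay, at which 2 of the 4 values shown sit.

The compounds shown leave open how weakly each of the two inhibits growth, and whether the exchange of groups on the carbon with a double bond to nitrogen changes that at all.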